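Moving a Halogen Around the Aryl Ring

This account rests on a few compounds, and the source may have more. Where it says the series, first, only, none or still open, it means among the compounds named here.

Of the compounds shown here, three sharing one core have been measured in a functional assay on MCF7 cells (Homo sapiens) for antiproliferative activity, read by sulforhodamine B assay, with a stated time of 48 h; on this read-out higher numbers stand for weaker inhibition of growth and lower numbers for stronger inhibition of growth. Compound 1 `NS(=O)(=O)NCC1CCN(c2cc(-c3ccc(Cl)cc3)ncn2)CC1` gives 25500 nM, compound 2 `NS(=O)(=O)NCC1CCN(c2cc(-c3ccc(C(F)(F)F)cc3)ncn2)CC1` gives 22500 nM, and compound 3 `NS(=O)(=O)NCC1CCN(c2cc(-c3cccc(Cl)c3)ncn2)CC1` gives 47100 nM, the highest of the three numbers. The two measured steps were small: a 1.1-fold lower number from compound 1 to compound 2 (0.05 log units; within the scatter) and a 1.8-fold higher number from compound 1 to compound 3 (0.27 log units; within the scatter). Compound 4 `NS(=O)(=O)NCC1CCN(c2cc(-c3ccccc3F)ncn2)CC1` differs from compound 3 by 2-fluorophenyl in place of 3-chlorophenyl on an aromatic carbon. Both measured steps, one a swap of the substituent and one a change of where it sits, stayed within the scatter, so the move to compound 4, which combines such a swap and such a change, is expected to leave this assay roughly where it stands, with a 1.2-fold lower number from compound 3 to compound 4 (0.07 log units; within the scatter) as the estimated step. Compound 4 is therefore expected to give 40000 nM, within 15000 nM to 100000 nM.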

Compound 4, concentration for 50% growth inhibition: 48500 nM
Compound 4: the middle estimate sits 1.2-fold (0.08 log units) below what was measured; the range from low to high includes it.
By their numbers in this assay, from the lowest: compounds 2, 1, 3 and 4 (each within the scatter of the next, the first and the last beyond it).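

Replacing 3-chlorophenyl with 2-fluorophenyl gives, in this assay, a 1.0-fold higher number from compound 3 to compound 4 (0.01 log units; within the scatter), while replacing 4-chlorophenyl with the same group gives a 1.9-fold higher number from compound 1 to compound 4 (0.28 log units; within the scatter). Here the halogen and its place on the aryl ring change together, and neither step leaves the scatter, so this joint change makes no clear difference to growth inhibition. Nothing available explains this flat result. Still open, on these data alone, is whether an amine or a carboxylic acid on the aryl ring would move the number beyond the scatter.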